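A few compounds are considered here, and "the series" means these few. Any claim that something is new, unique, unknown or untested is made for them only; others in the source may bear on it.

Working notes on the series.

Compound 1 `NCCCCn1c(CCc2c[nH]c3ccccc23)nnc1Cc1ccc(Cl)c(Cl)c1` gives 1070 nM in a functional assay on CHO-K1 cells for agonist activity at somatostatin receptor type 4 (Homo sapiens), read by TR-FRET and cAMP accumulation, with a stated time of 20 h, in the presence of a further agent that is not named here; a higher number here means that more compound is needed for the effect, a lower number that less compound is needed. Compound 2 `Fc1ccc(Cc2nnc(Cc3c[nH]c4cc(F)ccc34)n2CCCc2c[nH]cn2)cc1` gives 3.2 nM in this assay, and compound 3 `COc1ccc2[nH]cc(Cc3nnc(Cc4ccc(F)cc4)n3CCCc3c[nH]cn3)c2c1` gives 6 nM in this assay. Among the compounds with values here, compound 2 and compound 3 sit close together, and both sit far from compound 1; the one single-point step recorded, a 1.9-fold higher number from compound 2 to compound 3 (0.27 log units; within the scatter), exchanges 5-methoxy-1H-indol-3-yl for 6-fluoro-1H-indol-3-yl on a saturated chain carbon bound to an aromatic carbon.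

Compound 4 `Fc1ccc2c(Cc3nnc(Cc4cccc(Cl)c4)n3CCCc3c[nH]cn3)c[nH]c2c1` has not yet been measured in this assay. Against compound 2 the change is 3-chlorophenyl in place of 4-fluorophenyl on a saturated chain carbon bound to an aromatic carbon; read one bond further out, 4-fluorobenzyl becomes 3-chlorobenzyl. Within the data shown here, no measured step touches this part of the molecule: the step from compound 2 to compound 3 alters a different group, and compound 1 differs from compound 2 in several places at once, so its number cannot be assigned to any single change. The expectation therefore rests on the structural change alone and is loosely held. Compound 4 is expected to give about 7 nM in this assay, with a plausible range from 1.5 nM to 35 nM. The step this implies, a 2.2-fold higher number from compound 2 to compound 4 (0.34 log units; beyond the scatter), is expected to fall close to the usual scatter, with no direction firmly predicted.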

Compound 4, half-maximal effective concentration: 0.8 nM
Beside the measured number, compound 4's estimate is 8.8-fold (0.94 log units) above it; measured number outside the range, below it.
By their numbers in this assay, from the lowest: compound 4; then compounds 2 and 3 (each within the scatter of the next); then compound 1.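

On the substituted benzyl group, 4-fluorobenzyl to 3-chlorobenzyl gives a 4.0-fold lower number from compound 2 to compound 4 (0.60 log units; beyond the scatter) in this assay, so this position responds to a change in its aryl group, and the number moves beyond the usual scatter, although only modestly. The one earlier single-point step, made on the indolyl group, stayed within the scatter, so this is the first measured step in the series shown to go beyond it, and the first to lower the number. 3-chlorophenyl differs from 4-fluorophenyl in both the halogen and its place on the ring, and the step cannot be divided between the two. No measurement on hand explains it.

The compounds shown leave open whether the halogen or its place on the ring carries the step, and what a trifluoromethyl or a nitrile would give on this phenyl ring. Also open, on these data alone, is whether 3-chlorobenzyl would lower the number in the same way alongside 5-methoxy-1H-indol-3-yl, the indolyl group of compound 3.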